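A few compounds are considered here, and "the series" means these few. Any claim that something is new, unique, unknown or untested is made for them only; others in the source may bear on it.

Compound 1 `O=C(CN(C(=O)c1ccc(Cl)cc1)C1CCCCC1)Nc1cc(F)cc(F)c1` — 631 nM
Compound 2 `O=C(CN(C(=O)c1cccnc1)C1CCCCC1)Nc1cc(F)cc(F)c1` — > 25100 nM

The two measured compounds share one core and differ only in the group attached to a carbonyl carbon. In an assay on HEK293 cells for inhibition of sodium- and chloride-dependent glycine transporter 1 (Homo sapiens), read by scintillation proximity assay (on this read-out lower numbers stand for stronger inhibition and higher numbers for weaker inhibition), compound 1 gives 631 nM. Compound 2 reaches only a limit of the assay, > 25100 nM. Within the data shown here, compound 1 therefore holds the only true number among the values shown, the other value being a limit. Among the measured compounds shown here, the single measured step, an at least 39-fold higher number from compound 1 to compound 2 (1.59 log units; beyond the scatter), ends at the limit of > 25100 nM in this assay, at which 1 of the 2 values shown sits, and shows that the group on this carbonyl carbon matters strongly.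

Compound 3 `O=C(CN(C(=O)c1ccccc1Cl)C1CCCCC1)Nc1cc(F)cc(F)c1` has not been measured yet. It differs from compound 1 in this way: 2-chlorophenyl in place of 4-chlorophenyl on a carbonyl carbon. Here the chlorine is moved within the same ring rather than the ring being exchanged, so the measured step is only a loose guide; it indicates that changes at this carbonyl carbon can be large. A weaker result is expected, though short of the measured step. In this assay compound 3 is expected to give 2000 nM, with a range of 400 nM to 15000 nM. The expected step is a 3.2-fold higher number from compound 1 to compound 3 (0.50 log units; beyond the scatter).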

Compound 3, half-maximal inhibitory concentration: 20000 nM
The estimate for compound 3 lay 10-fold (1.00 log units) below the measured number; the whole stated range lies below it.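

The earlier pair exchanged the whole ring, but here the ring and its chlorine both stay, and only the chlorine's place differs: in this assay, going from 4-chlorophenyl to 2-chlorophenyl on the carbonyl carbon gives a 32-fold higher number from compound 1 to compound 3 (1.50 log units; beyond the scatter). This position is therefore sensitive not only to which ring is attached but also to where a single substituent sits on that ring, and compound 1 remains the most potent of the compounds shown. The comparison with the pyridin-3-yl compound gives an at least 1.2-fold lower number from compound 2 to compound 3 (0.09 log units; that floor lies within the scatter), so its floor does not put these two compounds in any order.

Compound 2 holds a limit of the assay rather than a true number: the limit of > 25100 nM in this assay, at which 1 of the 3 values shown sits.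

On these data alone, what remains open is how 3-chlorophenyl would compare with its 2-chloro and 4-chloro relatives, which would show whether only the 4-chlorophenyl arrangement gives the lower number. It is also unclear whether the pattern belongs to chlorine itself, a question that 2-methylphenyl and 4-methylphenyl, or 2-methoxyphenyl and 4-methoxyphenyl, would address at the same carbonyl carbon.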